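Difluoro pairs on a shared core: Nrf2 activation notes

The compounds below may be only part of what the source reports. "The series", "measured", "known", "first", "only" and "open" are said of these compounds alone.

Measured compounds in an assay on HepG2 cells for activation of nuclear factor erythroid 2-related factor 2 (Homo sapiens), read by a luciferase reporter, with a stated time of 5 h; a lower number here means that less compound is needed, a higher number that more compound is needed for the effect:
- compound 1, `Fc1cccc(/C=C/c2cccc(F)c2)c1`, gives 1000 nM
- compound 2, `Fc1ccc(/C=C/c2cccc(F)c2)cc1`, gives 650 nM
- compound 3, `Fc1cccc(/C=C/c2cc(F)ccc2F)c1`, gives 300 nM

Compound 2 has the same atoms as compound 1, joined differently; the difference between the two cores is not broken down here. Their values in this assay lie within the scatter of each other, so no order between compound 1 and compound 2 is read.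

Compound 3 carries one change against compound 1: fluoro in place of hydrogen on an aromatic carbon. In this assay this gave a 3.3-fold lower number from compound 1 to compound 3 (0.52 log units; beyond the scatter).

Compound 4, `Fc1ccc(/C=C/c2cc(F)ccc2F)cc1`, is not yet measured. It stands to compound 2 as compound 3 stands to compound 1: fluoro in place of hydrogen on an aromatic carbon. The place of the entering fluoro is the same, word for word, in both pairs, so this is the same change and occurs twice among the four compounds shown.

With a single earlier example to rest on, compound 4 is expected to sit lower than compound 2 by about the same amount, i.e. a 3.3-fold lower number from compound 2 to compound 4 (0.51 log units; beyond the scatter) is the estimated step, because a 3.3-fold lower number from compound 1 to compound 3 (0.52 log units; beyond the scatter) was found for the same change in the other pair. On that basis compound 4 is estimated at 200 nM in this assay, with an expected range from 90 nM to 500 nM; a single prior example leaves the range wide.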

Compound 4, half-maximal effective concentration: 2900 nM
The estimate for compound 4 lay 15-fold (1.16 log units) below the measured number; measured number above the stated range.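

In this assay, the same entry of fluoro in place of hydrogen on an aromatic carbon now gives a 4.5-fold higher number from compound 2 to compound 4 (0.65 log units; beyond the scatter), so the step seen on the core of compound 1 does not carry over to the core of compound 2. The two steps run in opposite directions, and the change therefore cannot be treated as transferable between these two closely related cores: the same change on two cores in this assay, a 3.3-fold lower number (0.52 log units; beyond the scatter) from compound 1 to compound 3 and a 4.5-fold higher number (0.65 log units; beyond the scatter) from compound 2 to compound 4, 15-fold (1.17 log units) apart, beyond the scatter of two such steps

Among the compounds shown here, this shows that the outcome of the change depends on the core it is made on, even though compound 1 and compound 2 themselves lie within the scatter of each other, but with only two pairs it does not show which feature of the cores decides the direction, nor does it give a rule for any further core.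

The compounds shown leave open whether another group entering at the same place, such as chloro, methoxy or an amine, would split between the two cores in the same way. Also open, as far as these compounds go, is whether a carboxylic acid or a longer chain at that place would follow either fluoro step on either core.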